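The compounds below may be only part of what the source reports. "The series", "measured", "known", "first", "only" and "open" are said of these compounds alone.

Compound 1 `O=C(Nc1cccc(-n2cc(-c3ccncc3)c(-c3cc(O)cc(Cl)c3)n2)c1)Nc1ccc(Cl)c(C(F)(F)F)c1` gives 2330 nM in a functional assay on A549 cells (Homo sapiens) for inhibition, read by sulforhodamine B assay, with a stated time of 48 h; on this read-out higher numbers stand for weaker inhibition and lower numbers for stronger inhibition. Compound 2 `COc1cc(Cl)cc(-c2nn(-c3cccc(NC(=O)Nc4ccc(Cl)c(C(F)(F)F)c4)c3)cc2-c2ccncc2)c1`, which carries methyl in place of hydrogen on an oxygen on an aromatic ring, gives 680 nM in this assay, and the step of a 3.4-fold lower number from compound 1 to compound 2 (0.53 log units; beyond the scatter) lies beyond the scatter. Compound 3 `COc1cc(Cl)cc(-c2nn(-c3cccc(NC(=O)Nc4cc(C(F)(F)F)cc(C(F)(F)F)c4)c3)cc2-c2ccncc2)c1` gives 370 nM in this assay; the values of compound 2 and compound 3 lie within the scatter of each other. Among these three numbers compound 2 thus stands second highest, apart from compound 3 by an amount within the scatter and apart from compound 1 by an amount beyond it.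

Compound 4 `COc1cc(Cl)cc(-c2nn(-c3cccc(NC(=O)c4cccc(C(F)(F)F)c4)c3)cc2-c2ccncc2)c1` differs from compound 2 in that (3-(trifluoromethyl)phenyl in place of (4-chloro-3-(trifluoromethyl)phenyl)amino on a carbonyl carbon). Within the data shown here, none of the measured steps touches this part of the molecule: the step from compound 1 to compound 2 concerns the oxygen on the aromatic ring, and the pair compound 2 and compound 3 shows only two values within the scatter. The expectation therefore rests on little, and compound 4 is estimated to lie at 1200 nM in this assay, with a range from 400 nM to 4000 nM. The implied step a 1.8-fold higher number from compound 2 to compound 4 (0.25 log units; within the scatter) is expected to be modest.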

Compound 4, half-maximal inhibitory concentration: 3620 nM
Beside the measured number, compound 4's estimate is 3.0-fold (0.48 log units) below it; low and high end bracket the measured number.
By their numbers in this assay, from the lowest: compounds 3 and 2 (each within the scatter of the next); then compounds 1 and 4 (each within the scatter of the next).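

Among these compounds, the first change at this position, on the carbonyl carbon, is not neutral: in this assay the replacement of (4-chloro-3-(trifluoromethyl)phenyl)amino by 3-(trifluoromethyl)phenyl gives a 5.3-fold higher number from compound 2 to compound 4 (0.73 log units; beyond the scatter), which means weaker inhibition by an amount beyond the scatter. Among the compounds shown here, the only step available earlier concerned the oxygen on the aromatic ring, so this is the first sign that this end of the molecule also matters for the read-out, although the single change removes an amino nitrogen with its hydrogen-bond donor and a chlorine together. No measurement offered here accounts for the shift.

The compounds shown leave open whether the nitrogen or the chlorine carries the difference. A methylene group in place of the amino nitrogen, with the chlorine kept on the ring, would help to separate the two.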